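Methoxy in place of methyl: notes on the series

This account rests on a few compounds, and the source may have more. Where it says the series, first, only, none or still open, it means among the compounds named here.

In a functional assay on CCRF-CEM cells (Homo sapiens), read by MTT assay, with a stated time of 3 days (on this read-out lower numbers stand for stronger inhibition and higher numbers for weaker inhibition), compound 1 (`c1csc(Sc2c[nH]c3ncnc(-c4cccs4)c23)c1`) gives 10600 nM. Compound 2 (`Cc1ncnc2[nH]cc(Sc3cccs3)c12`) gives > 50000 nM, which is a limit of the assay and not a number. Compound 3 (`COc1ncnc2[nH]cc(Sc3cccs3)c12`) has methoxy in place of methyl on an aromatic carbon. Within the data shown here, one measured step bears on this, an at least 4.7-fold higher number from compound 1 to compound 2 (0.67 log units; beyond the scatter), and it starts from thiophen-2-yl, so it gives no direct size for the methoxy change. The step expected in this assay is an at least 1.1-fold lower number from compound 2 to compound 3 (0.04 log units; that floor lies within the scatter), with none expected beyond the scatter in either direction. Compound 3 is estimated at 45000 nM, with an expected range of 15000 nM to 100000 nM.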

Compound 3, half-maximal inhibitory concentration: 18200 nM
Compound 3: the middle estimate sits 2.5-fold (0.39 log units) above what was measured, within the range that was stated.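

At this position of the shared core, methoxy gives a measured number in this assay where methyl does not: an at least 2.7-fold lower number from compound 2 to compound 3 (0.43 log units; beyond the scatter). That step is only a floor, as compound 2 stands at a limit of the assay and not at a number: the limit of > 50000 nM in this assay, at which 1 of the 3 values shown sits. Methoxy and thiophen-2-yl are not separated at this position: a 1.7-fold higher number from compound 1 to compound 3 (0.23 log units; within the scatter).

On these data alone, the full size of the methoxy step stays open. So does what an amine or a longer chain such as ethoxy would give on this aromatic carbon.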